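From Methyl to Pyridin-3-yl: What to Expect of Compound 4

The source may hold more compounds than are shown below. What is called first, only, known or untested is meant among the compounds shown, and "the series" means these compounds.

Compound 1 `CN(C(=O)c1cc(F)ccc1O)c1ccc(C#N)cc1`: > 10000 nM
Compound 2 `N#Cc1ccc(NC(=O)c2ccc(F)cc2O)cc1`: 3150 nM
Compound 3 `Cc1ccc(C(=O)Nc2ccc(C#N)cc2)c(O)c1`: 2560 nM

In a functional assay on KG-1 cells (Homo sapiens) for cytotoxicity, read by luminescence and CellTiter-Glo, with a stated time of 3 days (a higher number here means a weaker inhibitor, a lower number a stronger inhibitor), compound 1 gives only a limit, > 10000 nM (the limit of > 10000 nM in this assay, at which 1 of the 3 values shown sits). Compound 2 gives 3150 nM and compound 3 gives 2560 nM; the step of a 1.2-fold lower number from compound 2 to compound 3 (0.09 log units; within the scatter) lies within the scatter, so the two cannot be ordered. Compound 3 thus stands among the two numbered values without standing apart from compound 2. Compound 4 `N#Cc1ccc(NC(=O)c2ccc(-c3cccnc3)cc2O)cc1` differs from compound 3 by pyridin-3-yl in place of methyl on an aromatic carbon. Among the compounds with values here, no measured step exchanges a small alkyl group for an aromatic ring, and the one measured step was flat, so no direction beyond the scatter can be expected, only wide uncertainty. Compound 4 is estimated at 2000 nM (range 500 nM to 8000 nM), a step of a 1.3-fold lower number from compound 3 to compound 4 (0.11 log units; within the scatter).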

Compound 4, half-maximal inhibitory concentration: 7940 nM
Compound 4: middle estimate off by 4.0-fold (0.60 log units), on the low side; the range from low to high includes it.
By their numbers in this assay, from the lowest: compounds 3 and 2 (each within the scatter of the next); then compound 4. At a limit, above all of these: compound 1.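

The earlier exchange at this position, methyl in place of fluoro, stayed within the scatter, but in this assay pyridin-3-yl moves the number beyond it: a 3.1-fold higher number from compound 3 to compound 4 (0.49 log units; beyond the scatter) and a 2.5-fold higher number from compound 2 to compound 4 (0.40 log units; beyond the scatter). This position, meta to a hydroxy group and para to a large group, therefore responds to what sits on it, and here the larger aromatic ring gives a modestly weaker inhibitor. Nothing given here accounts for this shift. On these data alone, it remains open whether the ring itself or its nitrogen matters; a phenyl ring would separate the two. As far as these compounds go, how an amine or a carboxylic acid at this position would read also remains open.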